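Swapping One Halogenated Benzyl Ring for Another

The source may hold more compounds than are shown below. What is called first, only, known or untested is meant among the compounds shown, and "the series" means these compounds.

Of the compounds shown here, two have so far been measured in an ADME assay on cells (Mus musculus, strain BALB/c) for cytotoxicity, read by MTT assay, with a stated time of 24 h; on this read-out higher numbers stand for lower toxicity in this test and lower numbers for higher toxicity in this test. Compound 1 `COc1cc(-c2nnc(SCc3ccccc3F)o2)ccc1O` gives 474000 nM. Compound 2 `COc1cc(-c2nnc(SCc3ccc(Cl)cc3)o2)ccc1O` gives 480000 nM, which is the higher of the two numbers, yet its nearest neighbour compound 1 sits within the scatter of it: a 1.0-fold higher number from compound 1 to compound 2 (0.01 log units; within the scatter). Compound 3 `COc1cc(-c2nnc(SCc3ccc(F)cc3F)o2)ccc1O` has not been measured. It differs from compound 2 in one place: 2,4-difluorophenyl in place of 4-chlorophenyl on a saturated chain carbon bound to a sulfur. Among the measured compounds shown here, the only measured step that bears on this change also exchanges one substituted phenyl ring for another on the saturated chain carbon bound to a sulfur, and that exchange, a 1.0-fold higher number from compound 1 to compound 2 (0.01 log units; within the scatter), did not move the read-out beyond the scatter. With two different halogenated rings at this place giving the same number, the expected step of no change at the digits printed from compound 2 to compound 3 (within the scatter) is none beyond the scatter. Compound 3 is therefore estimated at 480000 nM in this assay, with a range from 240000 nM to 960000 nM to allow for the usual repeat-to-repeat spread.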

Compound 3, half-maximal cytotoxic concentration: 520000 nM
Beside the measured number, compound 3's estimate is 1.1-fold (0.03 log units) below it, and the stated range covers the measured number.
By their numbers in this assay, from the lowest: compounds 1, 2 and 3 (each within the scatter of the next).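

Placing 2,4-difluorophenyl in place of 4-chlorophenyl on a saturated chain carbon bound to a sulfur gives, in this assay, a 1.1-fold higher number from compound 2 to compound 3 (0.03 log units; within the scatter), and fluoro in place of hydrogen on an aromatic carbon gives a 1.1-fold higher number from compound 1 to compound 3 (0.04 log units; within the scatter). The earlier compounds shown here offered a single exchange of one halogenated ring for another, whereas three rings can now be compared: going from one halogen to two, and from chlorine to fluorine, leaves each of these steps within the scatter, so at this place the read-out does not separate these three halogenated phenyl rings. No measurement shown here explains why these rings read alike.

From the compounds shown here alone, all three rings carry only halogens, so what an amine or a carboxylic acid on this ring would do to the number stays open, as does the effect of a longer chain between the sulfur and the ring. The shared core is the same in all three compounds, so they also say nothing about how changes to it would affect this read-out.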